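A few compounds are considered here, and "the series" means these few. Any claim that something is new, unique, unknown or untested is made for them only; others in the source may bear on it.

In a functional assay on C-33-A cells (Homo sapiens) for antiproliferative activity, read by MTT assay (a lower number here means a stronger inhibitor, a higher number a weaker inhibitor), compound 1 (`Fc1ccc(N2CCN(c3nc(-n4ccc5ccccc54)c4ccccc4n3)CC2)cc1`) gives 50 ug/mL and compound 2 (`COc1ccc(-c2nc(N3CCNCC3)nc3ccccc23)c(OC)c1`) gives 50 ug/mL with no difference between them at the digits reported. Among the measured compounds shown here, compound 1 therefore stands level with the only other measured compound, and no measured pair differing in a single place is available to guide the next step.

That step leads to compound 3 (`c1ccc2c(c1)ccn2-c1nc(N2CCNCC2)nc2ccccc12`), which has not yet been measured in this assay. The change from compound 1 is hydrogen in place of 4-fluorophenyl on an amine nitrogen in a ring in which hydrogen replaces 4-fluorophenyl on an amine nitrogen in a ring, while the rest of compound 1 stays as it is.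

The data do not show directly what this replacement does. A clear shift in either direction is not expected because compound 2 at 50 ug/mL stands level with compound 1, which is thin but sole evidence. The expected change is a 1.3-fold lower number from compound 1 to compound 3 (0.10 log units; within the scatter) and is estimated to remain within the scatter. Compound 3 is estimated at 40 ug/mL with an expected range from 15 ug/mL to 100 ug/mL.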

Compound 3, half-maximal inhibitory concentration: 8.2 ug/mL
Estimate against measurement, compound 3: 4.9-fold (0.69 log units) above; measured number below the stated range.
By their numbers in this assay, from the lowest: compound 3; then compounds 1 and 2 (each within the scatter of the next).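

In this assay, among the compounds shown here, putting hydrogen in place of 4-fluorophenyl on an amine nitrogen in a ring gives a 6.1-fold lower number from compound 1 to compound 3 (0.79 log units; beyond the scatter), the only step in this set and one that lies beyond the scatter. It shows that this position is not indifferent to what it carries and that, with the rest of compound 1 unchanged, the large aromatic group can be removed with a gain in antiproliferative activity, which the level values of compound 1 and compound 2 could not show, as those two compounds differ in more than one place. The compounds shown offer no measurement that accounts for this step.

For the compounds shown here, the single step leaves open whether the gain depends on the hydrogen itself or simply on the loss of the 4-fluorophenyl, a question that a methyl, an acetyl or a short hydroxyethyl chain on the same nitrogen would help to settle. It also leaves open whether the fluorine plays any part, which a plain phenyl group at this position would test against compound 1.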